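Substituent on the aromatic tail: fluoro, nitro, then methoxy

The source may hold more compounds than are shown below. What is called first, only, known or untested is meant among the compounds shown, and "the series" means these compounds.

Compound 1 `O=c1[nH]/c(=N\OCCCc2ccc(F)cc2)ccn1[C@@H]1O[C@H](COP(=O)(O)OP(=O)(O)OP(=O)(O)O)[C@@H](O)[C@H]1O` gives 547 nM in a functional assay on 1321-N1 cells for agonist activity at P2Y purinoceptor 2 (Homo sapiens), read by scintillation counting and inositol phosphate accumulation; on this read-out lower numbers stand for an effect already at smaller amounts and higher numbers for an effect only at larger amounts of compound.
Compound 2 `O=c1[nH]/c(=N\OCCCc2ccc([N+](=O)[O-])cc2)ccn1[C@@H]1O[C@H](COP(=O)(O)OP(=O)(O)OP(=O)(O)O)[C@@H](O)[C@H]1O` gives 458 nM in this assay.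

Compound 2 carries the lower of the two numbers, but a 1.2-fold lower number from compound 1 to compound 2 (0.08 log units; within the scatter) keeps it within the scatter of compound 1. Compound 3 `COc1ccc(CCCO/N=c2/ccn([C@@H]3O[C@H](COP(=O)(O)OP(=O)(O)OP(=O)(O)O)[C@@H](O)[C@H]3O)c(=O)[nH]2)cc1` differs from compound 2 by methoxy in place of nitro on an aromatic carbon, para to a large group. Among the measured compounds shown here, the only step that bears on this exchange at the same aromatic carbon is a 1.2-fold lower number from compound 1 to compound 2 (0.08 log units; within the scatter), and it stayed within the scatter; no step beyond the scatter is therefore expected in this assay. Compound 3 is expected at 500 nM, with a range of 200 nM to 1300 nM, which would mean a 1.1-fold higher number from compound 2 to compound 3 (0.04 log units; within the scatter).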

Compound 3, half-maximal effective concentration: 47 nM
Estimate against measurement, compound 3: 11-fold (1.03 log units) above; measured number below the stated range.
By their numbers in this assay, from the lowest: compound 3; then compounds 2 and 1 (each within the scatter of the next).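

In this assay the substituent on the aromatic carbon para to a large group is not indifferent: methoxy in place of nitro gives a 9.7-fold lower number from compound 2 to compound 3 (0.99 log units; beyond the scatter) and methoxy in place of fluoro gives a 12-fold lower number from compound 1 to compound 3 (1.07 log units; beyond the scatter) while the exchange between fluoro and nitro stayed within the scatter. The two earlier compounds alone gave no sign of this sensitivity. Nothing available explains the difference.

Open, on these data alone, is whether ethoxy, hydroxy or an amine on the same carbon would keep the lower number, and whether methoxy gives the same step on a longer chain.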